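This account rests on a few compounds, and the source may have more. Where it says the series, first, only, none or still open, it means among the compounds named here.

Three compounds have been measured in a functional assay, with a stated time of 20 min; on this read-out higher numbers stand for weaker inhibition and lower numbers for stronger inhibition:
Compound 1 `CN(C)c1ccc(-c2nc(NN)n(C)c(=O)c2C#N)cc1` gives 81 ug/mL.
Compound 2 `CCOC(=O)c1cnn(-c2nc(-c3ccccc3O)c(C#N)c(=O)n2C)c1N` gives 48 ug/mL.
Compound 3 `CCOC(=O)c1cnn(-c2nc(-c3ccc(N(C)C)cc3)c(C#N)c(=O)n2C)c1N` gives 98 ug/mL.

On these numbers compound 3 stands highest of the three, which on this read-out means the weakest inhibition. Its nearest neighbour is compound 1, and the two lie within the scatter of each other, so no order between them can be read. The gap to compound 2 is larger: a 2.0-fold higher number from compound 2 to compound 3 (0.31 log units; beyond the scatter). That step swapped the 2-hydroxyphenyl of compound 2 for the 4-(dimethylamino)phenyl of compound 3, and the number rose modestly, beyond the scatter.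

Compound 4 `CCOC(=O)c1cnn(-c2nc(-c3ccccc3Cl)c(C#N)c(=O)n2C)c1N` has not been measured. It differs from compound 3 in one place: 2-chlorophenyl in place of 4-(dimethylamino)phenyl on an aromatic carbon. Going by the values given here, the only measured step that touches this position is the one from compound 2 to compound 3, and it concerns the very group that now leaves; compound 4 gives up what compound 3 gained in that step. A return toward the number of compound 2 therefore seems the likeliest outcome, though the entering group is not the hydroxyphenyl, and the size is less certain than the direction. A modest step downward in this assay is expected, of about a 1.8-fold lower number from compound 3 to compound 4 (0.25 log units; within the scatter). Compound 4 is accordingly estimated at 55 ug/mL, within a range from 25 ug/mL to 120 ug/mL.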

Compound 4, half-maximal inhibitory concentration: 78 ug/mL
Compound 4: the middle estimate sits 1.4-fold (0.15 log units) below what was measured, and the stated range covers the measured number.
By their numbers in this assay, from the lowest: compounds 2, 4, 1 and 3 (each within the scatter of the next, the first and the last beyond it).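

In this assay, replacing the 4-(dimethylamino)phenyl with 2-chlorophenyl gives a 1.3-fold lower number from compound 3 to compound 4 (0.10 log units; within the scatter) and so cannot be read as a real change at this carbon, which sits ortho to a cyano group. Chloro in place of hydroxy on the same phenyl ring gives a 1.6-fold higher number from compound 2 to compound 4 (0.21 log units; within the scatter) and so cannot be read as a real change either. Compound 4 therefore cannot be grouped with compound 2 or with compound 3, even though those two are separated by a 2.0-fold higher number from compound 2 to compound 3 (0.31 log units; beyond the scatter) and this intermediate result means the earlier gap alone does not firmly tie the higher number to the 4-(dimethylamino)phenyl group or the lower number to the 2-hydroxyphenyl group.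

What a plain phenyl, a 2-methoxyphenyl or a 2-aminophenyl would give at this carbon stays open, and with steps this small, no clear preference among these aryl groups can be drawn. No measurement of any other kind bears on these numbers, so what lies behind them remains unknown.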